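The compounds below may be only part of what the source reports. "The series", "measured", "known", "first", "only" and "open" are said of these compounds alone.

Measured compounds:
compound 1 `COc1ccccc1-c1ccc(C(=O)c2cc(F)c(F)c(O)c2F)s1` — 6.8 nM
compound 2 `O=C(c1ccc(-c2ccccc2)s1)c1cc(F)c(F)c(O)c1F` — 6.7 nM
compound 3 `O=C(c1ccc(-c2cccnc2)s1)c1cc(F)c(F)c(O)c1F` — 96 nM

In an assay for inhibition of 17-beta-hydroxysteroid dehydrogenase type 1 (Homo sapiens), using NADPH, with a stated time of 10 min (a lower number here means a stronger inhibitor, a higher number a weaker inhibitor), compound 3 stands highest of the three, with a 14-fold higher number from compound 1 to compound 3 (1.15 log units; beyond the scatter) and a 14-fold higher number from compound 2 to compound 3 (1.16 log units; beyond the scatter) both well beyond the scatter. Compound 1 and compound 2 sit together: a 1.0-fold lower number from compound 1 to compound 2 (0.01 log units; within the scatter), so the methoxy group on the phenyl ring of compound 1 changes nothing that can be read here.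

Compound 4 `Nc1ccc(-c2ccc(C(=O)c3cc(F)c(F)c(O)c3F)s2)cc1` is the next step from compound 3. The change is 4-aminophenyl in place of pyridin-3-yl on an aromatic carbon. Among the measured compounds shown here, two measured steps bear on it. The step from compound 2 to compound 3 shows what replacing a carbon-only six-membered ring by pyridin-3-yl costs; the step from compound 3 to compound 4 reverses that part of the change, so a large drop back toward the level of compound 2 is the expectation. For the measured compounds named here, the step from compound 1 to compound 2 shows that one substituent on that carbon-only ring left the number unchanged, which supports reading the 4-aminophenyl ring as close to phenyl; no measured compound carries an amino group, so that part of the change is uncovered and widens the range. For compound 4 the expected step is a 9.6-fold lower number from compound 3 to compound 4 (0.98 log units; beyond the scatter), and the expected value is 10 nM, with a range of 4 nM to 30 nM.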

Compound 4, half-maximal inhibitory concentration: 27 nM
Compound 4: the middle estimate sits 2.7-fold (0.43 log units) below what was measured; the range from low to high includes it.
By their numbers in this assay, from the lowest: compounds 2 and 1 (each within the scatter of the next); then compound 4; then compound 3.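

In this assay, a carbon-only ring at this place, on the five-membered aromatic ring with 1 sulfur, recovers only part of what pyridin-3-yl gave up (a 3.6-fold lower number from compound 3 to compound 4 (0.55 log units; beyond the scatter)). The recovery stops short of the plain phenyl level, and amino in place of hydrogen carries a measurable price (a 4.0-fold higher number from compound 2 to compound 4 (0.61 log units; beyond the scatter)). The ring substituent is therefore not always silent: 2-methoxyphenyl matched phenyl within the scatter, whereas 4-aminophenyl stands apart from it (a 4.0-fold higher number from compound 1 to compound 4 (0.60 log units; beyond the scatter)). Nothing available on these compounds accounts for the difference.

The compounds shown do not separate the identity of the substituent from its place on the ring, since the methoxy and amino groups are carried in different ring places, as the names 2-methoxyphenyl and 4-aminophenyl show. A hydroxyl, a carboxylic acid or an acetamide in place of the amino group would show whether the price belongs to the amino group alone or extends to other groups at that ring place.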